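The source may report more compounds than this note shows. Statements on the series, on what has been measured and on what is new or still open speak of the compounds shown alone.

In a functional assay on Huh-7 cells (Homo sapiens) for cytotoxicity, read by MTT assay, with a stated time of 72 h (a lower number here means that less compound is tolerated, a higher number that more compound is tolerated), compound 1 (`CS(=O)(=O)N1CCC2(CC1)OOC1(CCCCC1)OO2`) gives > 100 ug/mL as a limit and not a number. Compound 2 (`O=S(=O)(Cc1ccccc1)N1CCC2(CC1)OOC1(CCCCC1)OO2`) gives > 100 ug/mL and so also stands only at a limit. Going by the values given here, the one measured step is a step that the two limits leave unreadable from compound 1 to compound 2 and offers no size to carry forward. Compound 4 (`O=S(=O)(c1ccc(Br)cc1F)N1CCC2(CC1)OOC1(CCCCC1)OO2`) departs from compound 2 with 4-bromo-2-fluorophenyl in place of benzyl on a sulfonyl sulfur. Compound 3 (`O=S(=O)(c1ccc(Br)cc1F)N1CCC2(CC1)OOC1(CCCC1)OO2`), which also carries 4-bromo-2-fluorophenyl on a sulfonyl sulfur, gives > 100 ug/mL as a limit too. No change beyond the scatter is expected in this assay because of the limit of > 100 ug/mL in this assay, at which 3 of the 3 values shown sit, and that covers compound 1, compound 2 and compound 3 alike. The expected step is a step that the limit leaves unreadable from compound 2 to compound 4 in this estimate. Compound 4 is estimated at 130 ug/mL with an expected range from 60 ug/mL to 300 ug/mL in this assay.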

Compound 4, half-maximal cytotoxic concentration: > 100 ug/mL
Compound 4: no number, only a limit (the forecaster's own chance of this, stated with the estimate: 85%); the middle value lies beyond the limit too.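

The steps from compound 1 and from compound 2 to compound 4 cannot be read in this assay, as each compound stands only at a limit. The compounds shown leave open whether replacing benzyl with 4-bromo-2-fluorophenyl changes tolerance at all.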